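This account rests on a few compounds, and the source may have more. Where it says the series, first, only, none or still open, it means among the compounds named here.

Among the compounds with values here, in a functional assay on BXPC-3 cells (Homo sapiens) for antiproliferative activity, read by sulforhodamine B assay, with a stated time of 72 h (a higher number here means a weaker inhibitor, a lower number a stronger inhibitor), compound 1 (`O=C(c1ccccc1)c1cccc(/C=c2\[nH]c(=O)/c(=C/c3ccccn3)[nH]c2=O)c1`) gives 6.27 nM as the lowest of the three numbers measured so far, which makes it the strongest inhibitor of the set. Compound 2 (`CC(C)(C)c1[nH]cnc1/C=c1\[nH]c(=O)/c(=C/c2cccc(C(=O)N3CCCC3)c2)[nH]c1=O`) gives 325 nM in this assay and compound 3 (`CC(C)(C)c1[nH]cnc1/C=c1\[nH]c(=O)/c(=C/c2cccc(C(=O)N3CCCCC3)c2)[nH]c1=O`) gives 100 nM there.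

Compound 4 (`O=C(c1cccc(/C=c2\[nH]c(=O)/c(=C/c3ccccn3)[nH]c2=O)c1)N1CCC1`) has not been measured yet. It differs from compound 1 in a single group (azetidin-1-yl in place of phenyl on a carbonyl carbon) with azetidin-1-yl in place of phenyl on a carbonyl carbon, so benzoyl becomes (azetidin-1-yl)carbonyl.

Within the data shown here, compound 2 and compound 3 carry pyrrolidin-1-yl and piperidin-1-yl on a carbonyl carbon, and the one step between them (a 3.3-fold lower number from compound 2 to compound 3 (0.51 log units; beyond the scatter)) is modest but beyond the scatter. Among the measured compounds shown here, both also differ from compound 1 elsewhere on the core, so no measured step shows this exchange directly, and the comparison is only a loose guide. Even so, compound 3 at 100 nM and compound 2 at 325 nM both sit far above compound 1 at 6.27 nM and point to a weaker compound 4. The expected change is a large one toward a higher number (a 48-fold higher number from compound 1 to compound 4 (1.68 log units; beyond the scatter)) and lies well beyond the scatter. Compound 4 is estimated at 300 nM with an expected range from 70 nM to 1300 nM in this measurement.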

Compound 4, half-maximal inhibitory concentration in the BXPC-3 assay: > 500 nM
Compound 4 was reported as a limit; the forecaster's own chance of this, stated with the estimate: 3%; at least 1.6-fold (0.22 log units) between middle value and limit.
By their numbers in the BXPC-3 assay, from the lowest: compound 1; then compound 3; then compound 2. At a limit, above all of these: compound 4.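

Compounds 2 and 3 carry their amides on a different core, so they gave only an indirect hint, whereas this pair shows the exchange directly in the BXPC-3 assay: azetidin-1-yl in place of phenyl on a carbonyl carbon gives an at least 79-fold higher number from compound 1 to compound 4 (1.90 log units; beyond the scatter), so activity on the core of compound 1 depends strongly on the group at this place. In the BXPC-3 assay compound 4 gives > 500 nM, which is a limit of the assay and not a number. In a physicochemical assay for solubility, read by HPLC, with a stated time of 24 h (on this read-out higher numbers stand for higher solubility and lower numbers for lower solubility), compound 4 gives 0.662 ug/mL. In the physicochemical assay compound 1 gives < 0.1 ug/mL, which is a limit of the assay and not a number. The same exchange also shows a gain that the earlier compounds could not show, with the physicochemical assay giving an at least 6.6-fold higher number from compound 1 to compound 4 (0.82 log units; beyond the scatter), so the change that costs activity comes with higher solubility, although this comparison rests on a limit for compound 1: the limit of < 0.1 ug/mL in the physicochemical assay, at which 1 of the 2 values shown sits.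

A single pair cannot tell whether the loss in activity belongs to azetidin-1-yl itself or to any amide at this place on the core of compound 1. As far as these compounds go, it also remains open how a morpholin-4-yl or an open-chain dimethylamino group on the same carbonyl carbon would behave in the two read-outs.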